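Cyclopropyl in place of ethyl on the shared core

The source may report more compounds than this note shows. Statements on the series, on what has been measured and on what is new or still open speak of the compounds shown alone.

Among the measured compounds shown here, in a functional assay (aorta) with Rattus norvegicus as the target (a higher number here means a weaker inhibitor, a lower number a stronger inhibitor), compound 3 (`CCCCN(CCCC)CCCOc1ccc(S(=O)(=O)c2c(CC)cn3ccccc23)cc1`) gives 31.3 nM as the lowest of three numbers so far, against compound 2 (`CCCCN(CCCC)CCCOc1ccc(S(=O)(=O)c2c(C)cn3ccccc23)cc1`) at 162 nM and compound 1 (`CCCCN(CCCC)CCCOc1ccc(S(=O)(=O)c2c(-c3ccccc3)cn3ccccc23)cc1`) at 1620 nM in the same series.

Compound 4 (`CCCCN(CCCC)CCCOc1ccc(S(=O)(=O)c2c(C3CC3)cn3ccccc23)cc1`) carries cyclopropyl in place of ethyl on an aromatic carbon. For the measured compounds named here, three measured steps bear on this carbon: a 10-fold lower number from compound 1 to compound 2 (1.00 log units; beyond the scatter) for methyl in place of phenyl, a 52-fold lower number from compound 1 to compound 3 (1.71 log units; beyond the scatter) for ethyl in place of phenyl, and a 5.2-fold lower number from compound 2 to compound 3 (0.71 log units; beyond the scatter) for the added chain methyl. Going by the values given here, no measured compound carries cyclopropyl, so these steps set only the scale.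

A small rise or no change beyond the scatter is expected, and the estimated step is a 1.3-fold higher number from compound 3 to compound 4 (0.13 log units; within the scatter) in this assay for this replacement. For compound 4 the estimated value is 42 nM (expected range 12 nM to 140 nM).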

Compound 4, half-maximal inhibitory concentration: 10.9 nM
Compound 4: middle estimate off by 3.9-fold (0.59 log units), on the high side, and the stated range ends above it.
By their numbers in this assay, from the lowest: compound 4; then compound 3; then compound 2; then compound 1.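

In this assay the fall in the number does not stop at ethyl on this aromatic carbon: cyclopropyl in its place gives a 2.9-fold lower number from compound 3 to compound 4 (0.46 log units; beyond the scatter). The same group gives a 15-fold lower number from compound 2 to compound 4 (1.17 log units; beyond the scatter) and a 150-fold lower number from compound 1 to compound 4 (2.17 log units; beyond the scatter), so a ring here does not by itself raise the number, as phenyl sits highest and cyclopropyl lowest. Nothing available accounts for this difference.

On these data alone, whether isopropyl, cyclobutyl or a longer chain such as propyl lowers the number further remains open. So does whether the cyclopropyl gain holds with other amine chains on the shared core.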